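Methoxy on the hydroxy-bearing ring: an expected null step

This account rests on a few compounds, and the source may have more. Where it says the series, first, only, none or still open, it means among the compounds named here.

Measured in a functional assay on A549 cells (Homo sapiens) for antiproliferative activity, read by sulforhodamine B assay, with a stated time of 72 h; on this read-out lower numbers stand for stronger inhibition and higher numbers for weaker inhibition
Compound 1 `O=C(/C=C/c1csc2ccccc12)c1ccccc1O` gives 5300 nM
Compound 2 `CCOc1ccc(O)c(C(=O)/C=C/c2csc3ccccc23)c1` gives 5400 nM
Compound 3 `CC(C)Oc1ccc(O)c(C(=O)/C=C/c2csc3ccccc23)c1` gives 6400 nM

Compound 1 stands within the scatter of both other compounds. Compound 4 `COc1ccc(C(=O)/C=C/c2csc3ccccc23)c(O)c1` differs from it by methoxy in place of hydrogen on an aromatic carbon, meta to a hydroxy group and para to a large group (methoxy in place of hydrogen on an aromatic carbon). The nearest evidence comes from two alkoxy additions at a different aromatic carbon, a 1.0-fold higher number from compound 1 to compound 2 (0.01 log units; within the scatter) and a 1.2-fold higher number from compound 1 to compound 3 (0.08 log units; within the scatter). As far as these compounds go, neither step leaves the scatter, so no real shift is expected in this assay, although the new position remains untested. The expected step is a 1.1-fold lower number from compound 1 to compound 4 (0.03 log units; within the scatter). For compound 4 the estimated value is 5000 nM, with an expected range from 2200 nM to 11000 nM.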

Compound 4, half-maximal inhibitory concentration: 5600 nM
For compound 4 the middle estimate is 1.1-fold (0.05 log units) below the measured one; measured number inside the range.
By their numbers in this assay, from the lowest: compounds 1, 2, 4 and 3 (each within the scatter of the next).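

In this assay the methoxy group on the aromatic carbon meta to a hydroxy group and para to a large group gives a 1.1-fold higher number from compound 1 to compound 4 (0.02 log units; within the scatter), so this position now has its own direct reading. Like the different aromatic carbon carrying ethoxy in compound 2 and isopropoxy in compound 3, it takes an alkoxy group with no step beyond the scatter. No measurement shown bears on why and the result stands as an observation only. As far as these compounds go, whether an amine, a carboxylic acid or a longer alkoxy chain on this carbon would move the number remains open.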